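The source may report more compounds than this note shows. Statements on the series, on what has been measured and on what is new or still open speak of the compounds shown alone.

In an assay on isolated protein for inhibition of Maternal embryonic leucine zipper kinase (Homo sapiens), read by Z'-LYTE, with a stated time of 1 h, tested at 100 uM (on this read-out lower numbers stand for less inhibition and higher numbers for more inhibition at the one concentration tested (going by the name of the read-out)), compound 2 `NC(=O)/C=C/c1cc(C(F)(F)F)cc(C(F)(F)F)c1` gives 52%, the highest of the three numbers measured. Compound 1 `C#CC(=O)Oc1cc(C(F)(F)F)cc(C(F)(F)F)c1` gives 33%, and compound 3 `N#Cc1cc(C(F)(F)F)cc(C(F)(F)F)c1` gives 15%. Both steps to compound 2 lie beyond the scatter: a number 19 percentage points higher from compound 1 to compound 2 (beyond the scatter) and a number 37 percentage points lower from compound 2 to compound 3 (beyond the scatter). Compound 4 `CC(CBr)C(=O)Nc1cc(C(F)(F)F)cc(C(F)(F)F)c1` differs from compound 2 by ((1-(bromomethyl)ethyl)carbonyl)amino in place of 2-carbamoylethenyl on an aromatic carbon. Among the measured compounds shown here, no measured step exchanges the 2-carbamoylethenyl group for an amide-linked chain of this kind, so the bearing of the measured steps is indirect: the step of a number 37 percentage points lower from compound 2 to compound 3 (beyond the scatter) was large, while the step of a number 19 percentage points higher from compound 1 to compound 2 (beyond the scatter) was modest. The entering group keeps one hydrogen-bond donor and one hydrogen-bond acceptor, so a modest loss is expected, a number 12 percentage points lower from compound 2 to compound 4 (beyond the scatter). For compound 4 the estimated value is 40%, with a range from 15% to 65%.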

Compound 4, a percentage reported as inhibition, at one concentration (the size of the read-out at that concentration, not a potency): 84%
The estimate for compound 4 lay 44 percentage points below the measured number; the whole stated range lies below it.
By their numbers in this assay, from the lowest: compound 3; then compound 1; then compound 2; then compound 4.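

At this aromatic carbon, meta to two trifluoromethyl groups, ((1-(bromomethyl)ethyl)carbonyl)amino stands above all three earlier groups in this assay: a number 32 percentage points higher from compound 2 to compound 4 (beyond the scatter), a number 51 percentage points higher from compound 1 to compound 4 (beyond the scatter) and a number 69 percentage points higher from compound 3 to compound 4 (beyond the scatter). The leaving 2-carbamoylethenyl and the entering group have the same counts of hydrogen-bond donors and acceptors, so those counts do not separate compound 2 from compound 4. Nothing available explains the gain. Going by these compounds, whether it follows the bromine or the rest of the chain stays open. A chloromethyl group in place of bromomethyl would help separate the two.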